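From a Limit Towards a Number

The source may report more compounds than this note shows. Statements on the series, on what has been measured and on what is new or still open speak of the compounds shown alone.

Three compounds share the same core, and each has been tested in a functional assay on Bel7402/5-FU cells (Homo sapiens) for antiproliferative activity, read by MTT assay, with a stated time of 72 h; a higher number here means a weaker inhibitor, a lower number a stronger inhibitor. Compound 1 (`C=C1C(=O)O[C@H]2[C@H]1CC/C(COC(=O)Cn1cc(F)c(=O)[nH]c1=O)=C\CC[C@@]1(C)O[C@@H]21`) gives > 20000 nM as a limit of the assay and not a number. Compound 2 (`C=C1C(=O)O[C@H]2[C@H]1CC/C(COC(=O)CCC(=O)N1CCN(C(=O)Cn3cc(F)c(=O)[nH]c3=O)CC1)=C\CC[C@@]1(C)O[C@@H]21`) gives > 20000 nM as a limit too. Compound 1 therefore stands at the limit of > 20000 nM in this assay, at which 2 of the 3 values shown sit, and has no exact value of its own. Within the data shown here, compound 3 (`C=C1C(=O)O[C@H]2[C@H]1CC/C(Cn1cc(Cn3cc(F)c(=O)n(Cc4ccccc4)c3=O)nn1)=C\CC[C@@]1(C)O[C@@H]21`) gives 8840 nM as the only true number so far.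

Compound 4 (`C=C1C(=O)O[C@H]2[C@H]1CC/C(COC(=O)Cn1cc(F)c(=O)n(Cc3ccc(C(F)(F)F)cc3)c1=O)=C\CC[C@@]1(C)O[C@@H]21`) is compound 1 with a single change, a 4-(trifluoromethyl)benzyl in place of hydrogen on an aromatic nitrogen. Among the measured compounds shown here, no measured pair isolates a change of this kind, so its size can only be estimated. Compound 3 also carries a benzyl group on an aromatic nitrogen and gives 8840 nM in this comparison, although it is joined to the core differently. A modest move towards stronger inhibition is therefore expected, not a dramatic one, and the assay may again report only a limit. The expected move is an at least 2.0-fold lower number from compound 1 to compound 4 (0.30 log units; that floor lies within the scatter) and it remains an estimate resting on very few compounds. The estimated value for compound 4 in this assay is 10000 nM with an expected range of 3500 nM to 20000 nM around it.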

Compound 4, half-maximal inhibitory concentration: 2250 nM
For compound 4 the middle estimate is 4.4-fold (0.65 log units) above the measured one, outside the stated range (below it).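

Putting a 4-(trifluoromethyl)benzyl on the aromatic nitrogen, where compound 1 carries only hydrogen, is the one single change shown that turns a limit into a true number in this assay, and it gives an at least 8.8-fold lower number from compound 1 to compound 4 (0.94 log units; beyond the scatter). Compound 3 also carries a benzyl group on an aromatic nitrogen, but it is joined to the core differently as well, so it could not show what this position does on its own, whereas compound 4 differs from compound 1 in this one place. The size of the step is only a floor, because compound 1 has a limit of the assay and no exact number: the limit of > 20000 nM in this assay, at which 2 of the 4 values shown sit.

The compounds shown cannot separate the contribution of the benzyl ring from that of the trifluoromethyl group it carries, since compound 3 differs from compound 4 in more than one place. They also leave open how this nitrogen would respond to a small methyl group, a longer alkyl chain, or a benzyl ring bearing an amine or a carboxylic acid.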